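Adding a methoxy to compound 2

The source may report more compounds than this note shows. Statements on the series, on what has been measured and on what is new or still open speak of the compounds shown alone.

Measured compounds, read out in a functional assay on KB cells (Homo sapiens) for antiproliferative activity, with a stated time of 72 h; on this read-out lower numbers stand for stronger inhibition and higher numbers for weaker inhibition
compound 1 `COc1cc(C(=O)c2cccc3ncccc23)cc(OC)c1OC` gives 2900 nM
compound 2 `COc1cc(C(=O)c2ccc3ncccc3c2)cc(OC)c1OC` gives 24 nM
compound 3 `COc1cc(C(=O)c2cccc3cccnc23)cc(OC)c1OC` gives 8100 nM

Compound 2 has the lowest number of the three, and both other compounds lie far beyond the scatter above it. The step to compound 4 `COc1ccc2cc(C(=O)c3cc(OC)c(OC)c(OC)c3)ccc2n1` puts methoxy in place of hydrogen on an aromatic carbon, next to the ring nitrogen (methoxy in place of hydrogen on an aromatic carbon).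

Among the compounds with values here, no measured pair shows what such a replacement does, so the expectation is loose. The three values do show that the number can move far on this scaffold, with compound 2 at 24 nM and compound 3 at 8100 nM. A higher number is expected, with an estimated 3.3-fold higher number from compound 2 to compound 4 (0.52 log units; beyond the scatter) as a moderate step, a little beyond the scatter. In this assay compound 4 is estimated at 80 nM (expected range 12 nM to 600 nM).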

Compound 4, half-maximal inhibitory concentration: 301 nM
Compound 4: middle estimate off by 3.8-fold (0.58 log units), on the low side; measured number inside the range.
By their numbers in this assay, from the lowest: compound 2; then compound 4; then compound 1; then compound 3.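

In this assay, within the data shown here, methoxy in place of hydrogen on an aromatic carbon, next to the ring nitrogen, gives a 13-fold higher number from compound 2 to compound 4 (1.10 log units; beyond the scatter), the only step so far that isolates a single change. Among these compounds, this is the first direct sign that this carbon of the six-membered aromatic ring with 1 nitrogen is sensitive to substitution: a group of 2 heavy atoms here costs a large part of the potency of compound 2. Compound 4 still keeps a measurable value of 301 nM, so the change weakens inhibition without abolishing it.

Going by these compounds, whether the loss is specific to methoxy remains open, since a fluorine, a methyl or an amine on the same carbon would test how general it is. Also open, on these data alone, is whether methoxy on other carbons of this ring carries the same cost. Nothing shown gives a reason for the loss at this position.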